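Cytotoxicity notes: dimethylamino in place of piperazine

The source may report more compounds than this note shows. Statements on the series, on what has been measured and on what is new or still open speak of the compounds shown alone.

The series shares one core, carried by compound 1 `Cc1cc(C)cc(Cn2c(=O)cc(N=[N+]=[N-])n(Cc3ccccn3)c2=O)c1`, compound 2 `Cc1cc(C)cc(Cn2c(=O)cc(N3CCNCC3)n(Cc3ccccc3)c2=O)c1`, compound 3 `Cc1cc(C)cc(Cn2c(=O)cc(N=[N+]=[N-])n(CC#N)c2=O)c1` and the still unmeasured compound 4 `Cc1cc(C)cc(Cn2c(=O)cc(N(C)C)n(Cc3ccccc3)c2=O)c1`. In an ADME assay on MT4 cells (Homo sapiens) for cytotoxicity, read by MTT assay, with a stated time of 4 days (on this read-out lower numbers stand for higher toxicity in this test and higher numbers for lower toxicity in this test), compound 1 reaches only the assay limit of > 100000 nM. Compound 3 gives 60000 nM in this assay. Going by the values given here, compound 2 gives 16000 nM in this assay, the lowest of the two numbers measured so far, with compound 3 the nearest and clearly above it. Among the compounds with values here, the single step between measured compounds, an at least 1.6-fold lower number from compound 1 to compound 3 (0.22 log units; that floor lies within the scatter), changes a substituent on the saturated chain carbon bound to an aromatic nitrogen and rests on one limit, (the limit of > 100000 nM in this assay, at which 1 of the 3 values shown sits). The change from compound 2 to compound 4 is dimethylamino in place of piperazin-1-yl on an aromatic carbon. Within the data shown here, no measured pair alters this position on the aromatic carbon, so the one measured step does not bear on it, and nothing in the data points to a direction. The expectation is therefore a number for compound 4 close to that of compound 2, without a step beyond the scatter. a 1.3-fold higher number from compound 2 to compound 4 (0.10 log units; within the scatter) is the step expected. Compound 4 is thus estimated at 20000 nM in this assay, with a range from 7000 nM to 70000 nM.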

Compound 4, half-maximal cytotoxic concentration: 48000 nM
For compound 4 the middle estimate is 2.4-fold (0.38 log units) below the measured one, and the stated range covers the measured number.
By their numbers in this assay, from the lowest: compound 2; then compounds 4 and 3 (each within the scatter of the next). At a limit, above all of these: compound 1.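

Going by these compounds alone, the position on the aromatic carbon now has a measured step of its own, which the one earlier step, made on the saturated chain carbon, could not supply: in this assay the exchange gives a 3.0-fold higher number from compound 2 to compound 4 (0.48 log units; beyond the scatter) and so shows that the number responds to the group placed here. With the higher number standing for lower toxicity in this test, the open dimethylamino group is the less toxic of the two in this pair, which shares the benzyl group and the 3,5-dimethylbenzyl group. Within the data shown here, nothing measured so far accounts for the size or direction of this step.

The exchange removes the six-membered non-aromatic ring, the hydrogen-bond donor and part of the heavy atoms at once, so this single pair cannot show which of these differences goes with the step. Going by these compounds, what morpholin-4-yl, 4-methylpiperazin-1-yl or diethylamino would give at this position remains open, as does whether the step holds when a group other than benzyl is carried on the shared core.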